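The source may hold more compounds than are shown below. What is called first, only, known or untested is meant among the compounds shown, and "the series" means these compounds.

Three compounds share one core and differ only in the aromatic group carried on an aromatic nitrogen. Compound 1 is `Cc1cc(=O)n(-c2ccccc2C(F)(F)F)nc1C(=O)Nc1ccc(Oc2ncnc3sccc23)cc1`, compound 2 is `Cc1cc(=O)n(-c2ccccc2OC(F)(F)F)nc1C(=O)Nc1ccc(Oc2ncnc3sccc23)cc1` and compound 3 is `Cc1cc(=O)n(-c2cccc(F)c2)nc1C(=O)Nc1ccc(Oc2ncnc3sccc23)cc1`. In a functional assay on MCF7 cells (Homo sapiens) for cytotoxicity, read by MTT assay, with a stated time of 72 h (a lower number here means a stronger inhibitor, a higher number a weaker inhibitor), compound 2 gives 11000 nM and compound 3 gives 27200 nM. For compound 1 the this assay reports only a limit, > 40000 nM, and no number. Going by the values given here, of the two numbers known, compound 3 stands highest, with compound 2 the nearest: a 2.5-fold higher number from compound 2 to compound 3 (0.39 log units; beyond the scatter).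

Compound 4 is `Cc1ccc(-n2nc(C(=O)Nc3ccc(Oc4ncnc5sccc45)cc3)c(C)cc2=O)cc1`. It differs from compound 3 in one place: 4-methylphenyl in place of 3-fluorophenyl on an aromatic nitrogen. Two measured steps also swap the group on this nitrogen: the gap just given and an at least 1.4-fold lower number from compound 1 to compound 3 (0.16 log units; that floor lies within the scatter). A third, an at least 3.6-fold lower number from compound 1 to compound 2 (0.56 log units; beyond the scatter), swaps one small group for another on the same kind of ring. None of these steps is larger than modest, so for compound 4 a step within the scatter or only slightly beyond it is expected in this assay, with the estimated step being a 1.4-fold lower number from compound 3 to compound 4 (0.13 log units; within the scatter). Compound 4 is therefore expected to give 20000 nM, between 7000 nM and 60000 nM.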

Compound 4, half-maximal inhibitory concentration: > 40000 nM
Compound 4: no number, only a limit (the forecaster's own chance of this, stated with the estimate: 25%); middle value at least 2.0-fold (0.30 log units) away from the limit.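

The new step on this nitrogen is an at least 1.4-fold higher number from compound 3 to compound 4 (0.16 log units; that floor lies within the scatter), so on this floor alone the 4-methylphenyl group cannot be told apart from the 3-fluorophenyl group. Measured against the 2-(trifluoromethoxy)phenyl group, the same 4-methylphenyl group gives a clearer result, an at least 3.6-fold higher number from compound 2 to compound 4 (0.56 log units; beyond the scatter), and compound 2 stays the strongest of the four, with its steps to each of the others printed as beyond the scatter. Compound 1 and compound 4 both end in a limit rather than a number, so the step between them cannot be read: the limit of > 40000 nM in this assay, at which 2 of the 4 values shown sit.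

From the compounds shown here alone, how far the true value of compound 4 lies past its limit remains open, and so does any real ranking of compound 1 and compound 4. Also open is how this nitrogen would respond to a phenyl ring carrying an amine or a carboxylic acid, since every group shown here carries only methyl, fluorine, trifluoromethyl or trifluoromethoxy.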